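This account rests on a few compounds, and the source may have more. Where it says the series, first, only, none or still open, it means among the compounds named here.

Compound 3 `O=C(Oc1cccc(Cl)c1)c1cc2cc(CCl)ccc2oc1=O` is the starting point. In a functional assay on HT-1080 cells (Homo sapiens), read by transwell migration, with a stated time of 24 h, tested at 0.1 uM (on this read-out lower numbers stand for a stronger effect and higher numbers for a weaker effect at the one concentration tested), compound 3 gives 98.4%, the highest of the three numbers in hand. Compound 1 `CC(=O)OCc1ccc2oc(=O)c(C(=O)Oc3cccc(Cl)c3)cc2c1` gives 95.2% in this assay, and the step between them is a number 3.2 percentage points higher from compound 1 to compound 3 (within the scatter). Compound 2 `CC(=O)OCc1ccc2oc(=O)c(C(=O)Sc3cccc(Br)c3)cc2c1` gives 79.6% in this assay; the step there is a number 15.6 percentage points lower from compound 1 to compound 2 (beyond the scatter). Compound 4 `O=C(Oc1cccc(Cl)c1)c1cc2ccccc2oc1=O` has not yet been measured and differs from compound 3 by hydrogen in place of chloromethyl on an aromatic carbon. For the measured compounds named here, of the measured steps, only the one from compound 1 to compound 3 changes the group at this part of the shared core, and it stayed within the scatter, so no step beyond the scatter is expected in this assay. For compound 4 the estimate is 95%, with a range from 84% to 104%. The expected step is then a number 3.4 percentage points lower from compound 3 to compound 4 (within the scatter).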

Compound 4, a percentage reported as activity, at one concentration (the size of the read-out at that concentration, not a potency): 52.4%
Compound 4: the middle estimate sits 42.6 percentage points above what was measured, and the stated range ends above it.
By their numbers in this assay, from the lowest: compound 4; then compound 2; then compounds 1 and 3 (each within the scatter of the next).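

In this assay, the number falls sharply, a number 46 percentage points lower from compound 3 to compound 4 (beyond the scatter) when hydrogen replaces chloromethyl and a number 42.8 percentage points lower from compound 1 to compound 4 (beyond the scatter) when hydrogen replaces acetoxymethyl, so the effect at this concentration is much stronger without either group. Exchanging those two groups had stayed within the scatter, which made this aromatic carbon look unimportant; the comparison with hydrogen shows that it matters. No measurement here explains why. Going by these compounds, whether a methyl, a fluoro or an amine on this carbon would behave like hydrogen or like chloromethyl remains open. So does whether hydrogen would give a similar gain alongside the (3-bromophenyl)sulfanyl group.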